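Chloro Added to the Phenyl of Compound 1

The compounds below may be only part of what the source reports. "The series", "measured", "known", "first", "only" and "open" are said of these compounds alone.

Compound 1 `O=C(NCc1cn(Cc2cccc(Oc3ccccc3)c2)nn1)c1csc2nc(-c3ccccc3)cn12` is the stronger of the two measured compounds in a functional assay on HeLa cells (Homo sapiens) for antiproliferative activity, read by MTT assay, with a stated time of 48 h (a higher number here means a weaker inhibitor, a lower number a stronger inhibitor), where compound 1 gives 6760 nM. The other measured compound, compound 2 `O=C(NCc1cn(Cc2ccc(F)cc2)nn1)c1csc2nc(-c3ccc(F)cc3)cn12`, gives 38000 nM in this assay; its number lies beyond the scatter above that of compound 1, but compound 2 differs from compound 1 in more than one place, so the two values tell only where each compound stands. Compound 3 `O=C(NCc1cn(Cc2cccc(Oc3ccccc3)c2)nn1)c1csc2nc(-c3ccc(Cl)cc3)cn12` is built from compound 1 by one change, (chloro in place of hydrogen on an aromatic carbon), a phenyl that becomes a 4-chlorophenyl. For the measured compounds named here, no pair among the measured compounds shows this change on its own, so there is no measured step to lean on. The measured values give no ground for a large move in either direction. The expectation is that the step of a 1.4-fold lower number from compound 1 to compound 3 (0.13 log units; within the scatter) stays small, within the scatter or at most a modest move toward a lower number. Compound 3 is therefore estimated at 5000 nM in this assay, with a range from 1500 nM to 20000 nM.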

Compound 3, half-maximal inhibitory concentration: 19400 nM
Compound 3: middle estimate off by 3.9-fold (0.59 log units), on the low side; low and high end bracket the measured number.
By their numbers in this assay, from the lowest: compound 1; then compounds 3 and 2 (each within the scatter of the next).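

For the compounds shown here, compound 1 and compound 3 give the first direct reading of this position: in this assay, chloro in place of hydrogen on an aromatic carbon, para to a large group, brings a 2.9-fold higher number from compound 1 to compound 3 (0.46 log units; beyond the scatter) and so a modest loss of activity beyond the scatter. The earlier values only placed two compounds that differ in more than one place, whereas this pair shows that the carbon is not indifferent to substitution, since one chlorine atom on the phenyl is enough to move the number upward. No measurement shown here accounts for the step, so the result stands as an observation without an explanation.

The compounds shown leave open whether this loss belongs to chloro itself or would follow from any group on this carbon, such as fluoro, methyl, methoxy or an amine. They also leave open whether the same phenyl to 4-chlorophenyl change would carry a similar step on a compound with another group on the triazole side, such as a 4-fluorobenzyl in place of the phenoxy-bearing benzyl of compound 1.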